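The source may hold more compounds than are shown below. What is called first, only, known or untested is meant among the compounds shown, and "the series" means these compounds.

Three compounds sharing one core have been run in a functional assay on CHO cells for activation of 5-hydroxytryptamine receptor 1D (Homo sapiens), read by GTPgammaS binding (a higher number here means a larger maximal response, a lower number a smaller maximal response), so far. Compound 1, `O=S(=O)(NCC1CCN(CCCc2c[nH]c3ccc(-n4cnnc4)cc23)CC1)c1ccccc1`, gives 73% in this assay. Compound 2, `O[C@@H]1Cc2ccccc2[C@H]1NC1CCN(CCCc2c[nH]c3ccc(-n4cnnc4)cc23)CC1`, gives 75%. Compound 3, `c1ccc2c(c1)CCC2NC1CCN(CCCc2c[nH]c3ccc(-n4cnnc4)cc23)CC1`, gives 68%. Compound 3 carries the lowest of the three numbers, but the step of a number 5 percentage points lower from compound 1 to compound 3 (within the scatter) and the step of a number 7 percentage points lower from compound 2 to compound 3 (within the scatter) are both within the scatter, so the three values cannot be ordered on this evidence.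

Compound 4, `CN(Cc1ccsc1)C1CCN(CCCc2c[nH]c3ccc(-n4cnnc4)cc23)CC1`, is the next step from compound 3. Its change is methyl((thiophen-3-yl)methyl)amino in place of (2,3-dihydro-1H-inden-1-yl)amino on a saturated ring carbon. The measured steps that bear on it are those that also swap the group on that saturated ring carbon: a number 5 percentage points lower from compound 1 to compound 3 (within the scatter) and a number 2 percentage points higher from compound 1 to compound 2 (within the scatter), together with a number 7 percentage points lower from compound 2 to compound 3 (within the scatter). Every one of them stayed within the scatter, although none of them brought in a group lacking a hydrogen-bond donor or containing a sulfur atom, so the present change is not covered directly. On this evidence the expected step of a number 2 percentage points higher from compound 3 to compound 4 (within the scatter) is none beyond the scatter. The estimate for compound 4 in this assay is 70%, with a range from 55% to 85%.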

Compound 4, largest response reached (reported as efficacy), in percent of the reference or control that the assay uses: 93%
Beside the measured number, compound 4's estimate is 23 percentage points below it; measured number above the stated range.
By their numbers in this assay, from the lowest: compounds 3, 1 and 2 (each within the scatter of the next); then compound 4.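

In this assay, among the compounds shown here, the saturated ring carbon had so far held three different groups with no separation among them, but methyl((thiophen-3-yl)methyl)amino gives a number 25 percentage points higher from compound 3 to compound 4 (beyond the scatter) and, measured against the other two groups, a number 18 percentage points higher from compound 2 to compound 4 (beyond the scatter) and a number 20 percentage points higher from compound 1 to compound 4 (beyond the scatter). The position is therefore not indifferent to its substituent: all three steps lie beyond the scatter, which sets compound 4 apart from the other three, while those three remain within the scatter of one another. The entering group has a five-membered aromatic ring with a sulfur atom and 0 hydrogen-bond donors, but nothing measured here accounts for the rise.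

Compound 4 differs from each of the others in several features at once, so the compounds shown do not separate the contribution of the methyl on the amine from that of the thiophene ring. As far as these compounds go, it remains open whether ((thiophen-3-yl)methyl)amino without the methyl, or methyl(benzyl)amino with a phenyl ring in place of the thiophene, would keep the larger maximal response in this assay at this position.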